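The compounds below may be only part of what the source reports. "The series", "measured", "known", "first", "only" and "open" are said of these compounds alone.

Measured so far:
Compound 1, `Nc1nc(OCc2ccccc2)c2ncn(C3O[C@H](O)[C@@H](O)[C@H]3O)c2n1`, 244 uM.
Compound 2, `Nc1nc(OCc2ccccc2)c2ncn(C3CC(O)C(O)O3)c2n1`, 6 uM.
Compound 3, `CC(=O)Nc1nc(OCc2ccc(I)cc2)c2ncn(C3O[C@H](O)[C@@H](O)[C@H]3O)c2n1`, 82 uM.

In a functional assay on M4Beu cells for cytotoxicity against M4Beu cell line (Homo sapiens), in the presence of a further agent that is not named here (a lower number here means that less compound is needed, a higher number that more compound is needed for the effect), compound 1 gives 244 uM, and the step of a 41-fold lower number from compound 1 to compound 2 (1.61 log units; beyond the scatter) follows the change (4,5-dihydroxyoxolan-2-yl in place of 3,4,5-trihydroxyoxolan-2-yl on an aromatic nitrogen). Compound 3 differs from compound 1 in its core, and the difference between the two cores is not broken down here; in this assay compound 3 gives 82 uM, a lower number than compound 1. Compound 4, `CC(=O)Nc1nc(OCc2ccc(I)cc2)c2ncn(C3CC(O)C(O)O3)c2n1`, carries the same change on the core of compound 3: 4,5-dihydroxyoxolan-2-yl in place of 3,4,5-trihydroxyoxolan-2-yl on an aromatic nitrogen. Because a 41-fold lower number from compound 1 to compound 2 (1.61 log units; beyond the scatter) was a large step, the step from compound 3 to compound 4 is expected to be a 27-fold lower number from compound 3 to compound 4 (1.44 log units; beyond the scatter), though it rests on a single precedent. Compound 4 is therefore estimated at 3 uM in this assay, between 0.8 uM and 15 uM.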

Compound 4, concentration for half-maximal effect: 269 uM
Compound 4: middle estimate off by 90-fold (1.95 log units), on the low side, outside the stated range (above it).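

In this assay the change to 4,5-dihydroxyoxolan-2-yl on the aromatic nitrogen gives a 3.3-fold higher number from compound 3 to compound 4 (0.52 log units; beyond the scatter) and so does not carry over from the core of compound 1 to the core of compound 3, in either direction or size: the same change on two cores in this assay, a 41-fold lower number (1.61 log units; beyond the scatter) from compound 1 to compound 2 and a 3.3-fold higher number (0.52 log units; beyond the scatter) from compound 3 to compound 4, 130-fold (2.13 log units) apart, beyond the scatter of two such steps

These two pairs show that the outcome of this change can depend on the core. They do not show which difference between the two cores matters, or what the change would do on a third core.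

As far as these compounds go, it remains open how each part of that core difference acts on its own. From the compounds shown here alone, it also remains open whether an amine in place of a hydroxy group on the oxolane ring would follow either step.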